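Dropping a Chloro Group from a Small Series

The source may hold more compounds than are shown below. What is called first, only, known or untested is meant among the compounds shown, and "the series" means these compounds.

Of the compounds shown here, two that share one core have been tested in an assay on membranes from brain for binding affinity to adenosine receptor A1 (Rattus norvegicus), read by radioligand binding, tested at 20 uM; a higher number here means more inhibition at the concentration tested (going by the name of the read-out), a lower number less inhibition. Compound 1, `Cn1c(=O)[nH]c2c(cnn2-c2cc(Cl)cc(Cl)c2)c1=N`, gives 29% in this assay. Compound 2, `Cn1c(=O)[nH]c2c(cnn2-c2ccccc2Cl)c1=N`, gives 7% in this assay, the lower of the two numbers, and the gap down from compound 1 lies beyond the scatter. Compound 3, `Cn1c(=O)[nH]c2c(cnn2-c2ccccc2)c1=N`, has not yet been measured in this assay. It differs from compound 2 in one place: hydrogen in place of chloro on an aromatic carbon. For the measured compounds named here, no measured pair shows this exact change, so its size has to be guessed rather than read off. Because compound 2 gives 7%, the starting number is already low, leaving little room to fall. The step of a number 3 percentage points higher from compound 2 to compound 3 (within the scatter) is expected to be small, within the scatter, with no clear direction. Compound 3 is therefore expected to give 10% in this assay, with a likely range from 0% to 25%.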

Compound 3, a percentage reported as inhibition, at one concentration (the size of the read-out at that concentration, not a potency): 30%
Beside the measured number, compound 3's estimate is 20 percentage points below it, and the stated range ends below it.
By their numbers in this assay, from the lowest: compound 2; then compounds 1 and 3 (each within the scatter of the next).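

In this assay, the first measured view of this change gives a number 23 percentage points higher from compound 2 to compound 3 (beyond the scatter), so replacing chloro with hydrogen on an aromatic carbon, ortho to a large group, is not a neutral swap in this series. The step with that one heavy atom gone lies beyond the scatter of repeat measurements. Here the chloro goes with the lower number. No measurement shown here accounts for this shift.

The compounds shown leave open whether this step is specific to chloro or would also appear with another group at the same place, such as fluoro, methyl or an amine. This single pair, read at one concentration, also cannot show how the change would affect potency.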